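Moving from a silicon group to a methoxyphenyl on the triazole

The compounds below may be only part of what the source reports. "The series", "measured", "known", "first", "only" and "open" are said of these compounds alone.

Of the compounds shown here, three sharing one core have been measured in a functional assay on HepG2 cells (Homo sapiens) for antiproliferative activity, read by MTT assay, with a stated time of 72 h; a lower number here means a stronger inhibitor, a higher number a weaker inhibitor. Compound 1 `COc1ccccc1-c1cn(C[C@H](O)[C@H]2OC(=O)C(OCc3ccccc3)=C2OCc2ccccc2)nn1` gives only the assay limit there, > 100000 nM. Compound 2 `O=C1O[C@H]([C@@H](O)Cn2cc(-c3cc(F)cc(F)c3)nn2)C(OCc2ccccc2)=C1OCc1ccccc1` gives 11600 nM, and compound 3 `C[Si](C)(C)c1cn(C[C@H](O)[C@H]2OC(=O)C(OCc3ccccc3)=C2OCc2ccccc2)nn1` gives 24100 nM. Among the two numbers that are not limits, compound 3 stands highest: the step of a 2.1-fold higher number from compound 2 to compound 3 (0.32 log units; beyond the scatter) runs beyond the scatter, while the step of an at least 4.1-fold lower number from compound 1 to compound 3 (0.61 log units; beyond the scatter) shows that the trimethylsilyl group of compound 3 gave a lower number than the 2-methoxyphenyl of compound 1.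

Compound 4 `COc1ccc(-c2cn(C[C@H](O)[C@H]3OC(=O)C(OCc4ccccc4)=C3OCc3ccccc3)nn2)cc1` differs from compound 3 as follows: a group of 8 heavy atoms (7 carbon, 1 oxygen; one six-membered aromatic ring of carbon only) in place of a group of 4 heavy atoms (3 carbon, 1 silicon; no ring), on an aromatic carbon. The change bearing on it most closely is the step of an at least 4.1-fold lower number from compound 1 to compound 3 (0.61 log units; beyond the scatter) taken in reverse, since compound 4 carries a methoxyphenyl, as compound 1 does, though with the methoxy at another position, and the step of an at least 8.6-fold lower number from compound 1 to compound 2 (0.93 log units; beyond the scatter) also shows an aryl group giving a lower number than that of compound 1.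

Compound 4 is therefore expected to give a higher number than compound 3, by about a 2.5-fold higher number from compound 3 to compound 4 (0.40 log units; beyond the scatter), and the estimate for compound 4 is 60000 nM, with a range from 20000 nM to 200000 nM.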

Compound 4, half-maximal inhibitory concentration: 46400 nM
Beside the measured number, compound 4's estimate is 1.3-fold (0.11 log units) above it; low and high end bracket the measured number.
By their numbers in this assay, from the lowest: compound 2; then compounds 3 and 4 (each within the scatter of the next). At a limit, above all of these: compound 1.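

At this aromatic carbon, a carbon-only aromatic ring does not by itself set a compound apart from the silicon group: in this assay, a 1.9-fold higher number from compound 3 to compound 4 (0.28 log units; within the scatter) stays within the scatter. The aryl groups do separate among themselves, as 4-methoxyphenyl in place of 3,5-difluorophenyl gives a 4.0-fold higher number from compound 2 to compound 4 (0.60 log units; beyond the scatter). Moving the methoxy group, with 4-methoxyphenyl in place of 2-methoxyphenyl, gives an at least 2.1-fold lower number from compound 1 to compound 4 (0.33 log units; beyond the scatter), and this step remains only a bound, with compound 1 at a limit of the assay: the limit of > 100000 nM in this assay, at which 1 of the 4 values shown sits.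

On these data alone, what a plain phenyl, an aminophenyl or a carboxylic acid at this carbon would give in this assay remains open. So does whether a single fluorine on the phenyl ring would read like 3,5-difluorophenyl or like 4-methoxyphenyl.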